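Adding one methyl to a hydroxy group of compound 1

A few compounds are considered here, and "the series" means these few. Any claim that something is new, unique, unknown or untested is made for them only; others in the source may bear on it.

Among the compounds with values here, in a functional assay for inhibition, with a stated time of 30 min (a lower number here means a stronger inhibitor, a higher number a weaker inhibitor), compound 1 (`O=C(/C=C/c1ccc(O)c(O)c1)OCCOc1no[n+]([O-])c1S(=O)(=O)c1ccccc1`) gives 221 nM as the lowest number so far. Within the data shown here, compound 2 (`O=C(OCCOc1no[n+]([O-])c1S(=O)(=O)c1ccccc1)c1ccc(O)c(O)c1`) gives 713 nM as the only other measured value. Compound 3 (`COc1cc(/C=C/C(=O)OCCOc2no[n+]([O-])c2S(=O)(=O)c2ccccc2)ccc1O`) has not yet been measured. It differs from compound 1 by a single change (methyl in place of hydrogen on an oxygen on an aromatic ring), methyl in place of hydrogen on an oxygen on an aromatic ring, which turns 3,4-dihydroxyphenyl into 4-hydroxy-3-methoxyphenyl. Among the measured compounds shown here, no measured step makes this exact change. The nearest evidence is a 3.2-fold higher number from compound 1 to compound 2 (0.51 log units; beyond the scatter) on placing 3,4-dihydroxyphenyl where 2-(3,4-dihydroxyphenyl)ethenyl stood on a carbonyl carbon. That step alters a different part of the molecule, so it offers only a rough guide to size. A modest step of similar or smaller size therefore seems reasonable, more likely towards a higher number, although the data cannot settle the direction. The estimated step is a 1.4-fold higher number from compound 1 to compound 3 (0.13 log units; within the scatter) in this assay as a best guess. For compound 3 the estimated value is 300 nM with an expected range from 100 nM to 900 nM in this measurement.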

Compound 3, half-maximal inhibitory concentration: 5130 nM
Compound 3: middle estimate off by 17-fold (1.23 log units), on the low side, and the stated range ends below it.
By their numbers in this assay, from the lowest: compound 1; then compound 2; then compound 3.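

In this assay, turning 3,4-dihydroxyphenyl into 4-hydroxy-3-methoxyphenyl gives a 23-fold higher number from compound 1 to compound 3 (1.37 log units; beyond the scatter), so a change of only 1 heavy atom on this oxygen makes a large difference. Of the two changes shown, this one weighs more than removing the ethenyl link, which gave a 3.2-fold higher number from compound 1 to compound 2 (0.51 log units; beyond the scatter). The free hydroxy group at this place therefore emerges as a sensitive point in compound 1, although no separate measurement here explains why the step is so large.

Methyl is the only replacement for this hydrogen shown, so it remains open whether an ethyl group on the same oxygen, or an amine in place of the hydroxy group, would give a similar result. Also open, on these data alone, is whether adding a methyl to the remaining hydroxy group of compound 1 would have a similar effect, and whether the same hydroxy-to-methoxy change would cost as much on compound 2, which lacks the ethenyl link.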